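From 3,4-difluorobenzyl to isopentyl on a shared core

The source may hold more compounds than are shown below. What is called first, only, known or untested is meant among the compounds shown, and "the series" means these compounds.

Of the compounds shown here, two have so far been tested in an in vitro ADME assay on microsomes from liver (Homo sapiens) for metabolic stability; on this read-out lower numbers stand for a shorter-lived compound and higher numbers for a longer-lived compound. Compound 1 `CS(=O)(=O)Nc1ccc2c(c1)S(=O)(=O)N=C(C1=C(O)C3CCCCCCC3N(Cc3ccc(F)cc3)C1=O)N2` gives > 1 h, which is a limit of the assay and not a number. Compound 2 `CS(=O)(=O)Nc1ccc2c(c1)S(=O)(=O)N=C(C1=C(O)[C@H]3CCC[C@H]3N(Cc3ccc(F)c(F)c3)C1=O)N2` gives > 1 h, which is likewise a limit. Compound 2 therefore stands with compound 1 at the only position seen so far, (the limit of > 1 h in this assay, at which 2 of the 2 values shown sit), and neither has an exact half-life.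

Compound 3 `CC(C)CCN1C(=O)C(C2=NS(=O)(=O)c3cc(NS(C)(=O)=O)ccc3N2)=C(O)[C@H]2CCC[C@H]21` keeps the core of compound 2 and differs in one place: isobutyl in place of 3,4-difluorophenyl on a saturated chain carbon bound to an amide-type nitrogen in a ring. In words, isobutyl takes the place of 3,4-difluorophenyl on a saturated chain carbon bound to an amide-type nitrogen in a ring. Cut one bond further out, this reads 3,4-difluorobenzyl to isopentyl.

Among the measured compounds shown here, no measured pair shows the size of such a change, so no step beyond the usual scatter is expected in this assay, and neither direction is favoured. The expected change is a step that the limit leaves unreadable from compound 2 to compound 3. Compound 3 is estimated at 1.5 h, with an expected range from 0.6 h to 4 h.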

Compound 3, half-life: 0.383 h
Beside the measured number, compound 3's estimate is 3.9-fold (0.59 log units) above it, outside the stated range (below it).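

In this assay, putting isobutyl in place of 3,4-difluorophenyl on a saturated chain carbon bound to an amide-type nitrogen in a ring gives an at least 2.6-fold lower number from compound 2 to compound 3 (0.41 log units; beyond the scatter), so this position does bear on the read-out and this change moves it towards a shorter-lived compound. On these data alone, the printed size is only a floor, as the starting point of the step is a limit of the assay, and how far the true gap extends stays unknown. Compound 3 also gives the series its first exact half-life and is the only compound shown that stands apart from this shared position: the limit of > 1 h in this assay, at which 2 of the 3 values shown sit.

What the compounds shown leave open is whether the lower number goes with the loss of the aromatic ring, of the two fluorines, or of both, a question that a plain benzyl or a cyclohexylmethyl group at this position would help to separate. They also leave open how a longer chain, or a chain ending in an amine or a carboxylic acid, would behave here on the same core.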